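The source may hold more compounds than are shown below. What is called first, only, known or untested is meant among the compounds shown, and "the series" means these compounds.

Going by the values given here, in a functional assay on SGC-7901 cells (Homo sapiens) for antiproliferative activity, read by MTT assay, with a stated time of 72 h (a lower number here means a stronger inhibitor, a higher number a weaker inhibitor), compound 2 `COc1ccc(-c2ccc3ncn(-c4cc(OC)c(OC)c(OC)c4)c3c2)cc1` gives 82 nM, the lowest of the two numbers measured so far; compound 1 `COc1cc(-n2cnc3ccc(-c4cccc(F)c4)cc32)cc(OC)c1OC` gives 2490 nM. Among the compounds with values here, only one measured step bears on the change at hand: a 30-fold lower number from compound 1 to compound 2 (1.48 log units; beyond the scatter), a large drop that came with exchanging a halogen-bearing phenyl for a phenyl carrying a methoxy group. Compound 3 `COc1cc(-n2cnc3ccc(-c4ccc(Cl)cc4Cl)cc32)cc(OC)c1OC` reverses that kind of exchange: 2,4-dichlorophenyl in place of 4-methoxyphenyl on an aromatic carbon. The group that enters is again a halogenated phenyl, though with two chlorines rather than one fluorine, and the single hydrogen-bond acceptor of the 4-methoxyphenyl is lost. On the strength of the step from compound 1 to compound 2, a large move to a higher number is expected for compound 3, though not necessarily all the way back to the figure of compound 1, estimated as an 11-fold higher number from compound 2 to compound 3 (1.04 log units; beyond the scatter). Compound 3 is therefore expected to give about 900 nM, within a range from 200 nM to 4000 nM.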

Compound 3, half-maximal inhibitory concentration: > 10000 nM
Compound 3 was reported as a limit (the forecaster's own chance of this, stated with the estimate: 3%); middle value at least 11-fold (1.04 log units) from the limit.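

In this assay the figure for compound 3 is a limit and not a number: the limit of > 10000 nM in this assay, at which 1 of the 3 values shown sits. Placing 2,4-dichlorophenyl on this aromatic carbon of the shared core instead of 4-methoxyphenyl gives an at least 120-fold higher number from compound 2 to compound 3 (2.08 log units; beyond the scatter), so the large sensitivity of this position to the group it carries now shows up in a second exchange. Halogenated phenyl groups also do not behave as one class here, since 2,4-dichlorophenyl in place of 3-fluorophenyl gives an at least 4.0-fold higher number from compound 1 to compound 3 (0.60 log units; beyond the scatter). The compounds shown leave open whether a phenyl carrying an amine or a carboxylic acid would stay near compound 2 or fall towards compound 3. They also leave open how a phenyl bearing a single chlorine would compare, and how far the true figure for compound 3 lies beyond its limit.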